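Carbamate half-life: phenyl to ethyl on the chain

The source may report more compounds than this note shows. Statements on the series, on what has been measured and on what is new or still open speak of the compounds shown alone.

Compound 1, `O=C(NCCCCc1ccccc1)Oc1cccc(-c2ccccc2)c1`, was measured in a physicochemical assay for pharmacokinetics, read by HPLC, at pH 9.0 (on this read-out lower numbers stand for a shorter-lived compound and higher numbers for a longer-lived compound), where compound 1 gives 0.713 h. Within the data shown here, its only measured neighbour is compound 2, `NC(=O)c1cccc(-c2cccc(OC(=O)NCCCCc3ccccc3)c2)c1`, which in this assay gives 0.505 h. The step from one to the other, a 1.4-fold lower number from compound 1 to compound 2 (0.15 log units; within the scatter), changes an aromatic position of the shared core and lies within the scatter, so compound 1 and compound 2 sit together on the two numbers shown.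

Compound 3, `CCCCCCNC(=O)Oc1cccc(-c2ccccc2)c1`, has not yet been measured. It differs from compound 1 in a single place: ethyl in place of phenyl on a saturated chain carbon, four bonds along the chain from an amide-type nitrogen. Among the measured compounds shown here, no measured step touches that part of the molecule; the only step known concerns an aromatic carbon of the core, and it was within the scatter. There is therefore nothing in the measured pairs that points to a shift in either direction, and the expectation is a step no larger than the scatter. On that basis the half-life of compound 3 in this assay is estimated at 0.75 h, within a range of 0.38 h to 1.5 h, meaning an expected step of a 1.1-fold higher number from compound 1 to compound 3 (0.02 log units; within the scatter).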

Compound 3, half-life: 1.14 h
Estimate against measurement, compound 3: 1.5-fold (0.18 log units) below; the measured number falls inside the stated range.
By their numbers in this assay, from the lowest: compounds 2, 1 and 3 (each within the scatter of the next, the first and the last beyond it).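

In this assay, among these compounds, the exchange of phenyl for ethyl on a saturated chain carbon, four bonds along the chain from an amide-type nitrogen, comes to a 1.6-fold higher number from compound 1 to compound 3 (0.20 log units; within the scatter) and gives the first reading for a change on the chain, since the earlier step concerned an aromatic carbon of the core. Phenyl, with its 6 heavy atoms and its aromatic ring, gives way here to ethyl, with 2 heavy atoms and no ring, and the half-life stays within the scatter, so this single pair shows no need for that ring at this place. Nothing measured here speaks to what lies behind this step.

The compounds shown leave open how the half-life responds to other groups at this place, such as an amine, a carboxylic acid, a cyclohexyl ring or a longer chain. They also leave open whether ethyl in place of phenyl reads the same on a core that carries the carbamoyl group of compound 2.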